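Azetidine amide in place of primary amide

The source may report more compounds than this note shows. Statements on the series, on what has been measured and on what is new or still open speak of the compounds shown alone.

Compound 1 `CCN(CC)C(=O)[C@@H]1CN[C@H](C(=O)N2CCC[C@H]2C#N)C1` has no result in an assay on the whole organism (plasma, strain Sprague-Dawley) for inhibition of Dipeptidyl peptidase 4 (Rattus norvegicus), with a stated time of 10 h, at a dose of 1 mg/kg by the oral route (on this read-out higher numbers stand for more inhibition at the one dose given (going by the name of the read-out) and lower numbers for less inhibition), and is recorded there as "not determined" (no result reported). Going by the values given here, compound 2 `N#C[C@@H]1CCCN1C(=O)[C@@H]1C[C@H](C(N)=O)CN1` gives 20% in this assay, the only number in the set. Compound 3 `N#C[C@@H]1CCCN1C(=O)[C@@H]1C[C@H](C(=O)N2CCC2)CN1` differs from compound 2 by azetidin-1-yl in place of amino on a carbonyl carbon, a change that turns the carbamoyl into an (azetidin-1-yl)carbonyl on a carbonyl carbon whose other neighbour is a saturated ring carbon. Among the compounds with values here, with no measured step of this kind available, the expected step of a number 8 percentage points higher from compound 2 to compound 3 (within the scatter) is small and within the usual scatter. Compound 3 is therefore estimated at 28%, with a likely range from 5% to 60%.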

Compound 3, a percentage reported as inhibition, in the whole organism at one dose (the size of the read-out at that dose, not a potency): 46%
Compound 3: middle estimate off by 18 percentage points, on the low side; the measured number falls inside the stated range.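

In this assay, azetidin-1-yl in place of amino on this carbonyl carbon gives a number 26 percentage points higher from compound 2 to compound 3 (beyond the scatter). This shows that the position takes a four-membered ring on the amide nitrogen and that, at this one dose, inhibition rises rather than falls. Nothing in the data at hand accounts for the gain. The compounds shown leave open whether pyrrolidin-1-yl or morpholin-4-yl on the same carbonyl carbon would extend this step. They also leave open how a carboxylic acid would read out in its place.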